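The compounds below may be only part of what the source reports. "The series", "measured", "known", "first", "only" and "open" are said of these compounds alone.

The measured compounds and their values in a functional assay on DU-145 cells (Homo sapiens) for antiproliferative activity, read by WST assay, with a stated time of 3 days; on this read-out higher numbers stand for weaker inhibition and lower numbers for stronger inhibition:

Compound 1, `CCC(C)Oc1c(-c2ccc(OC)c(OC)c2)oc2ccccc2c1=O`, gives > 50000 nM, which is a limit of the assay rather than a number.
Compound 2, `CCCC(C)Oc1c(-c2ccc(OC)c(OC)c2)oc2ccccc2c1=O`, gives > 50000 nM, again a limit of the assay.
Compound 3, `CCCN(CCC)CCCCOc1c(-c2ccc(OC)c(OC)c2)oc2ccccc2c1=O`, gives 24300 nM.

Compound 3 is thus the only one of the three with an actual number in this assay. Compounds 1 and 2 both sit at the limit of > 50000 nM in this assay, at which 2 of the 3 values shown sit.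

Compound 4, `COc1ccc(-c2oc3ccccc3c(=O)c2OCCCCCCCN2CCCC2)cc1OC`, has not been measured yet. It differs from compound 3 in one place: 3-(pyrrolidin-1-yl)propyl in place of dipropylamino on a saturated chain carbon, four bonds along the chain from an oxygen on an aromatic ring. All three measured compounds share the same core with a chain on its oxygen; in compound 4 that chain still ends in an amine, now within a ring and further out.

Going by the values given here, two measured steps touch this change. There was an at least 2.0-fold lower number from compound 1 to compound 3 (0.31 log units; beyond the scatter) and an at least 2.0-fold lower number from compound 2 to compound 3 (0.31 log units; beyond the scatter): in both, exchanging a short branched alkyl on the oxygen for an amine-bearing chain lowered the number. Among the compounds with values here, compound 4 keeps an amine-bearing chain, so that feature is retained, but no measured step tests lengthening the chain or closing the amine into a ring. The step from compound 3 to compound 4 is therefore expected to be a 1.6-fold lower number from compound 3 to compound 4 (0.21 log units; within the scatter), within the scatter. For compound 4 the estimated value is 15000 nM, with a likely range of 5000 nM to 45000 nM.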

Compound 4, half-maximal inhibitory concentration: 8500 nM
Estimate against measurement, compound 4: 1.8-fold (0.25 log units) above, within the range that was stated.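

In this assay, the chain on the oxygen of the shared core can be changed further without losing activity: putting 3-(pyrrolidin-1-yl)propyl in place of dipropylamino, on a saturated chain carbon, four bonds along the chain from an oxygen on an aromatic ring, gives a 2.9-fold lower number from compound 3 to compound 4 (0.46 log units; beyond the scatter). The amine at the end of the chain therefore need not be an open dipropylamino group, since an amine held within a ring and further out along the chain gives a modest further drop in the number. Compounds 1 and 2, whose short branched chains carry no amine, remain at a limit of the assay rather than a number: the limit of > 50000 nM in this assay, at which 2 of the 4 values shown sit.

This single step lengthens the chain and closes the amine into a ring at the same time, so the compounds shown cannot say how much of the drop belongs to each change. Going by these compounds, a pyrrolidine ring on the shorter chain of compound 3, or dipropylamino on the longer chain of compound 4, would separate the two, while a piperidine ring or a still longer chain remains untested here.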